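The source may report more compounds than this note shows. Statements on the series, on what has been measured and on what is new or still open speak of the compounds shown alone.

Within the data shown here, in a functional assay on WI-38 cells (Homo sapiens) for inhibition (a lower number here means a stronger inhibitor, a higher number a weaker inhibitor), compound 2, whose structure is `CCC(C)C(NC(=O)NO)C(=O)NC(c1ccccc1)c1ccccc1`, gives 95800 nM, the only actual number among the three results gathered so far. Compound 1, with the structure `CCC(C)C1NC(=O)N(C2CCCCC2)C1=O`, gives > 100000 nM, which is a limit of the assay and not a number. Compound 3, with the structure `CCC(C)C1NC(=O)N(C2CCCC2)C1=O`, gives > 100000 nM, again a limit. Compound 2 thus stands just short of the limit of > 100000 nM in this assay, at which 2 of the 3 values shown sit. Compound 4, with the structure `CCC(C)C(NC(=O)n1nnc2ccccc21)C(=O)NC(c1ccccc1)c1ccccc1`, differs from compound 2 in one place: a group of 9 heavy atoms (6 carbon, 3 nitrogen; one five-membered aromatic ring with 3 hetero atoms, one six-membered aromatic ring of carbon only) in place of a group of 2 heavy atoms (1 nitrogen, 1 oxygen; no ring), on a carbonyl carbon. Among the measured compounds shown here, no measured pair shows such a change, so its direction cannot be read from the data. The step from compound 2 to compound 4 is expected to be a 1.6-fold higher number from compound 2 to compound 4 (0.19 log units; within the scatter), toward weaker inhibition or within the scatter. Compound 4 is expected to give about 150000 nM in this assay, within 40000 nM to 600000 nM, quite possibly reported only as a limit.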

Compound 4, half-maximal inhibitory concentration: 62700 nM
Compound 4: middle estimate off by 2.4-fold (0.38 log units), on the high side; low and high end bracket the measured number.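

Placing the two-ring group on the carbonyl carbon instead of hydroxyamino gives a 1.5-fold lower number from compound 2 to compound 4 (0.18 log units; within the scatter) in this assay. The hydroxyamino group, with its hydrogen-bond donors, is therefore not required for the weak inhibition seen with compound 2, since compound 4 has no donors in the group that replaces it. Both compounds still give actual numbers, but the measurable range ends at a limit: the limit of > 100000 nM in this assay, at which 2 of the 4 values shown sit.

As far as these compounds go, whether a smaller group on that carbonyl carbon, such as a plain amine or a methoxy group, would behave the same remains open. So does whether any group there can move the number beyond the scatter.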